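The source may report more compounds than this note shows. Statements on the series, on what has been measured and on what is new or still open speak of the compounds shown alone.

In a functional assay on HepG2 cells (Homo sapiens) for antiproliferative activity, read by MTT assay, with a stated time of 48 h (a lower number here means that less compound is needed, a higher number that more compound is needed for the effect), compound 1 `CC1=NN(C(=O)CCl)C(c2cc(Cl)ccc2O)C1` gives 20300 nM. Two related compounds lie within the usual scatter of that value: compound 2 `CC1=NN(C(=O)CBr)C(c2ccccc2O)C1` at 14400 nM and compound 3 `COc1ccc(C(=O)N2N=C(C)CC2c2ccccc2O)cc1` at 40300 nM. Compound 1 therefore cannot be told apart from either of them. Compound 4 `CC1=NN(C(=O)CCl)C(c2cc(F)ccc2O)C1` keeps the core of compound 1 and makes a single change: fluoro in place of chloro on an aromatic carbon, para to a hydroxy group. For the measured compounds named here, no measured pair here shows this swap, so the data do not size it directly, and no shift beyond the scatter is expected in this assay in either direction. The expected change is a 1.2-fold higher number from compound 1 to compound 4 (0.07 log units; within the scatter). Compound 4 is estimated at 24000 nM, with an expected range of 11000 nM to 50000 nM.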

Compound 4, half-maximal effective concentration: 4210 nM
The estimate for compound 4 lay 5.7-fold (0.76 log units) above the measured number; the whole stated range lies above it.
By their numbers in this assay, from the lowest: compound 4; then compounds 2, 1 and 3 (each within the scatter of the next, the first and the last beyond it).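

At the aromatic carbon para to a hydroxy group, replacing chloro with fluoro in this assay gives a 4.8-fold lower number from compound 1 to compound 4 (0.68 log units; beyond the scatter), the only step shown here between compounds that differ in one place. This exchange of one heavy atom for another is therefore enough to move the number beyond the scatter. No measurement shown here accounts for the shift.

From the compounds shown here alone, it remains open whether a methyl or a nitrile at this position would give a similar step. Going by these compounds, it is also open whether the step would persist with a different group on the core's carbonyl.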